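A few compounds are considered here, and "the series" means these few. Any claim that something is new, unique, unknown or untested is made for them only; others in the source may bear on it.

Measured compounds in a functional assay on CHO-K1 cells for antagonist activity at adenosine receptor A2b (Homo sapiens), read by FLIPR and calcium flux; on this read-out lower numbers stand for stronger inhibition and higher numbers for weaker inhibition:
- compound 1, `O=C(c1cncs1)c1nc(NCc2cccnc2)nc2ccsc12`, 148 nM
- compound 2, `Cc1ccc(C(=O)c2nc(NCc3cccnc3)nc3ccsc23)cc1`, 215 nM
- compound 3, `O=C(c1ccncc1)c1nc(NCc2cccnc2)nc2ccsc12`, 869 nM

Compound 3 gives the highest number of the three in this assay. Its nearest neighbour is compound 2, with a step of a 4.0-fold higher number from compound 2 to compound 3 (0.61 log units; beyond the scatter); the step from the lowest number is a 5.9-fold higher number from compound 1 to compound 3 (0.77 log units; beyond the scatter). Between compound 1 and compound 2 the step is a 1.5-fold higher number from compound 1 to compound 2 (0.16 log units; within the scatter), so the thiazolyl and the methylphenyl ketones sit together and the pyridinyl ketone stands apart from both.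

Compound 4, `O=C(NC1CC1)c1nc(NCc2cccnc2)nc2ccsc12`, is not yet measured. It differs from compound 3 in one place: cyclopropylamino in place of pyridin-4-yl on a carbonyl carbon. Among the measured compounds shown here, none of the measured steps exchanges an aromatic ring on the carbonyl carbon for an amine, so no step bears directly on this change. The three measured steps only show that the group on the carbonyl carbon can move the number in this assay by a modest amount, from within the scatter up to the step from compound 1 to compound 3. The change to compound 4 is larger in kind than any of those, so the range must stay wide. Compound 4 is expected to land near the middle of the measured set, a step of a 2.2-fold lower number from compound 3 to compound 4 (0.34 log units; beyond the scatter), with an estimate of 400 nM and a range from 100 nM to 2000 nM.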

Compound 4, half-maximal inhibitory concentration: 256 nM
For compound 4 the middle estimate is 1.6-fold (0.19 log units) above the measured one; the measured number falls inside the stated range.
By their numbers in this assay, from the lowest: compounds 1, 2 and 4 (each within the scatter of the next); then compound 3.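

Notes on the group on the carbonyl carbon: in this assay this position accepts a group that is not an aromatic ring, as cyclopropylamino in place of pyridin-4-yl gives a 3.4-fold lower number from compound 3 to compound 4 (0.53 log units; beyond the scatter) and the change is beyond the scatter. Against the other two ketones the amide shows a 1.2-fold higher number from compound 2 to compound 4 (0.08 log units; within the scatter) and a 1.7-fold higher number from compound 1 to compound 4 (0.24 log units; within the scatter), both within the scatter, so compound 1, compound 2 and compound 4 form one group despite their different attachments, and among these four compounds only compound 3 stands apart. No measurement at hand explains this difference or the place of compound 4.

Cyclopropylamino is the only amine shown on this carbonyl carbon, so it remains open whether the result extends to other amines, such as dimethylamino, which has no amide hydrogen, or a longer open-chain alkylamino group. As far as these compounds go, it is also open whether the higher number of compound 3 belongs to pyridin-4-yl alone or would also appear with pyridin-3-yl or pyridin-2-yl on the same carbon.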